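Lengthening the alkyl chain on the core of compound 3

This account rests on a few compounds, and the source may have more. Where it says the series, first, only, none or still open, it means among the compounds named here.

Compound 1, `CCCCCCCCCCc1c(C)c(N(C)C)nc(C)c1O`: 86%
Compound 2, `Cc1c(N(C)C)nc(CCCCCCCCCCO)c(O)c1C`: 74%
Compound 3, `CCCCCCCCCCc1nc(N(C)C)c(C)c(C)c1O`: 79%

These three compounds were tested in a functional assay on cells (Lymphocyte, Homo sapiens), read by trypan blue exclusion, with a stated time of 16 h, tested at 2.5 uM; on this read-out higher numbers stand for a stronger effect at the one concentration tested and lower numbers for a weaker effect. Compound 3 stands second highest of the three numbers; its nearest neighbour is compound 2, and the step of a number 5 percentage points higher from compound 2 to compound 3 (within the scatter) lies within the scatter, while compound 1 gives a number that is also within the scatter of compound 3.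

The next compound, compound 4, `CCCCCCCCCCCCCCCCCCCc1nc(N(C)C)c(C)c(C)c1O`, differs from compound 3 by nonyl in place of hydrogen on a saturated chain carbon, ten or more bonds along the chain from an aromatic carbon. Among the compounds with values here, none of the measured steps changes the length of this chain; the only step measured at the far end of the chain, the step of a number 5 percentage points higher from compound 2 to compound 3 (within the scatter), swapped a hydroxy for a hydrogen and stayed within the scatter. That is the closest guide, and it argues for no step beyond the scatter in this assay. Compound 4 is therefore expected to give about 75%, with a range from 55% to 90%, meaning an expected step of a number 4 percentage points lower from compound 3 to compound 4 (within the scatter).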

Compound 4, a percentage reported as activity, at one concentration (the size of the read-out at that concentration, not a potency): 66%
Compound 4: middle estimate off by 9 percentage points, on the high side; the measured number falls inside the stated range.
By their numbers in this assay, from the lowest: compounds 4, 2, 3 and 1 (each within the scatter of the next, the first and the last beyond it).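

Adding nonyl in place of hydrogen at the far end of the chain is the first change here to move the number in this assay beyond the usual scatter, giving a number 13 percentage points lower from compound 3 to compound 4 (beyond the scatter). So, for this pair on the shared core, the longer chain does not strengthen the effect, whereas the comparison with the hydroxy-ended chain gives a number 8 percentage points lower from compound 2 to compound 4 (within the scatter), which leaves those two compounds unseparated. No measurement shown here accounts for the lower number.

On these data alone, whether the number falls steadily as the chain grows or only past a certain length stays open, and a chain of intermediate length would speak to that. A chain ending in an amine or a carboxylic acid would show how far other groups at this far end are tolerated.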